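This account rests on a few compounds, and the source may have more. Where it says the series, first, only, none or still open, it means among the compounds named here.

Of the compounds shown here, three built on one shared core have been measured in a functional assay on the whole organism (strain Swiss albino) for inhibition, with Mus musculus as the target, read by paw edema, with stated times of 30 min and 180 min, at a dose of 100 mg/kg by the subcutaneous route; a lower number here means less inhibition, a higher number more inhibition at the dose given (going by the name of the read-out). Compound 1 `Cc1ccc(-c2cc(C(=O)Oc3ccc(C(C)(C)C)cc3)n(Cc3ccccc3)n2)cc1` gives 35%. Compound 2 `CCCCCCCOc1ccc(OC(=O)c2cc(-c3ccc(C)cc3)nn2Cc2ccccc2)cc1` gives 9%, and compound 3 `Cc1ccc(-c2cc(C(=O)Oc3ccc(Oc4ccc(C(F)(F)F)cc4)cc3)n(Cc3ccccc3)n2)cc1` gives 17%. Among these three numbers compound 3 stands second highest: compound 2 is its nearest neighbour and lies within the scatter of it, while compound 1 lies beyond the scatter above it. The measured steps are a number 26 percentage points lower from compound 1 to compound 2 (beyond the scatter), a number 18 percentage points lower from compound 1 to compound 3 (beyond the scatter) and a number 8 percentage points higher from compound 2 to compound 3 (within the scatter).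

Compound 4 `Cc1ccc(-c2cc(C(=O)Oc3ccc(-n4ccnc4)cc3)n(Cc3ccccc3)n2)cc1` is not yet measured. It differs from compound 3 in one place: 1H-imidazol-1-yl in place of 4-(trifluoromethyl)phenoxy on an aromatic carbon. Within the data shown here, no measured step involves an imidazolyl group, so nothing directly tells how this change behaves. What bears on it are the two earlier changes at the same aromatic carbon: both changes away from tert-butyl lowered inhibition beyond the scatter, and the exchange of one oxygen-linked group for another, from compound 2 to compound 3, stayed within the scatter. Compound 4 is therefore expected to remain in the same modest region as compound 3, with no step beyond the scatter. This amounts to an expected step of a number 3 percentage points higher from compound 3 to compound 4 (within the scatter). Compound 4 is estimated at 20%, with a range from 5% to 40%.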

Compound 4, a percentage reported as inhibition, in the whole organism at one dose (the size of the read-out at that dose, not a potency): 15.4%
The estimate for compound 4 lay 4.6 percentage points above the measured number; the range from low to high includes it.
By their numbers in this assay, from the lowest: compounds 2, 4 and 3 (each within the scatter of the next); then compound 1.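

In this assay, putting 1H-imidazol-1-yl in place of 4-(trifluoromethyl)phenoxy on this aromatic carbon gives a number 1.6 percentage points lower from compound 3 to compound 4 (within the scatter), and putting it in place of heptyloxy gives a number 6.4 percentage points higher from compound 2 to compound 4 (within the scatter), so a five-membered aromatic ring with 2 hetero atoms, attached without an oxygen, falls within the scatter of both oxygen-linked groups. Against tert-butyl the same group gives a number 19.6 percentage points lower from compound 1 to compound 4 (beyond the scatter), which extends the drop seen with the two oxygen-linked groups to a nitrogen-linked ring, and none of the three replacements goes against this pattern. Nothing available here explains why three such different groups end up so close together or why compound 1 stands apart from them.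

The compounds shown leave open whether the higher number of compound 1 belongs to tert-butyl alone or would also appear with other carbon-linked alkyl groups such as isopropyl or cyclohexyl. They also leave open whether an amine or a carboxylic acid on this aromatic carbon would stay with compounds 2, 3 and 4 or move beyond the scatter of them.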